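The compounds below may be only part of what the source reports. "The series", "measured", "known", "first", "only" and "open" are said of these compounds alone.

Measured so far in an assay on isolated protein for inhibition of advanced glycosylation end product-specific receptor (Homo sapiens), read by FRET, with stated times of 30 min and 1 h, tested at 4 uM; a higher number here means more inhibition at the concentration tested (going by the name of the read-out), a lower number less inhibition:

compound 1, `CC(C)N1CCC(Oc2ccc(-c3nc4ccc(Oc5ccc(Cl)cc5)cc4o3)cc2)CC1`: 12.7%
compound 2, `Clc1ccc(Oc2ccc3nc(-c4ccc(OCCCN5CCCCC5)cc4)oc3c2)cc1`: 2.2%
compound 3, `CN1CCN(CCCOc2ccc(-c3nc4ccc(Oc5ccc(Cl)cc5)cc4o3)cc2)CC1`: 24.3%

Compound 2 gives the lowest of the three numbers; the nearest measured value lies a number 10.5 percentage points lower from compound 1 to compound 2 (beyond the scatter), the furthest a number 22.1 percentage points higher from compound 2 to compound 3 (beyond the scatter). Compound 4, `FC(F)(F)c1cccc(Oc2ccc3nc(-c4ccc(OCCCN5CCCCC5)cc4)oc3c2)c1`, differs from compound 2 by 3-(trifluoromethyl)phenyl in place of 4-chlorophenyl on an oxygen on an aromatic ring. Every measured step, a number 10.5 percentage points lower from compound 1 to compound 2 (beyond the scatter), a number 11.6 percentage points higher from compound 1 to compound 3 (beyond the scatter) and a number 22.1 percentage points higher from compound 2 to compound 3 (beyond the scatter), changes the group on the other oxygen on an aromatic ring; none touches the 4-chlorophenoxy side that changes here. Among the compounds with values here, no measured step therefore bears directly on this change, and nothing supports a step beyond the scatter in either direction. The step to compound 4 is expected to be a number 3.8 percentage points higher from compound 2 to compound 4 (within the scatter). Compound 4 is estimated at 6% in this assay, with a range from 0% to 20%.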

Compound 4, a percentage reported as inhibition, at one concentration (the size of the read-out at that concentration, not a potency): 42.7%
Compound 4: the middle estimate sits 36.7 percentage points below what was measured; measured number outside the range, above it.
By their numbers in this assay, from the lowest: compound 2; then compound 1; then compound 3; then compound 4.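

On the aryl group carried by an oxygen on an aromatic ring, 3-(trifluoromethyl)phenyl in place of 4-chlorophenyl gives a number 40.5 percentage points higher from compound 2 to compound 4 (beyond the scatter) in this assay. This side of the molecule therefore matters, and this step is larger than any step measured on the other oxygen. No measured property accounts for this step, so its cause stays unassigned.

The step changes both the group and its ring location, so 3-chlorophenyl or 4-(trifluoromethyl)phenyl would be needed to separate the two. From the compounds shown here alone, whether 3-(trifluoromethyl)phenyl gives a similar step alongside the 3-(4-methylpiperazin-1-yl)propyl group of compound 3 also remains open.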